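Replacing the Sulfur Group at the Far End of the Core

The compounds below may be only part of what the source reports. "The series", "measured", "known", "first", "only" and "open" are said of these compounds alone.

Of the compounds shown here, three that share one core have been measured in an assay on HeLa cells with Bile acid receptor (Homo sapiens) as the target, read by a luciferase reporter, with a stated time of 24 h; a lower number here means that less compound is needed, a higher number that more compound is needed for the effect. Compound 1 `CC(C)(C)c1ccc(C(=O)NCc2ccc(N)cc2Cl)cc1` gives 46 nM in this assay, compound 2 `CC(C)(C)c1ccc(C(=O)NCc2ccc(SC(F)(F)F)cc2)cc1` gives 0.4 nM, and compound 3 `CC(C)(C)c1ccc(C(=O)NCc2ccc(C(=O)O)cc2Cl)cc1` gives 7500 nM. Compound 2 therefore stands at the lowest of the three numbers; compound 1 sits nearest to it, and compound 3 lies furthest away. Among the measured compounds shown here, the only step between two compounds differing in a single place is a 160-fold higher number from compound 1 to compound 3 (2.21 log units; beyond the scatter).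

The next compound, compound 4 `CC(C)(C)c1ccc(C(=O)NCc2ccc(S(C)(=O)=O)cc2)cc1`, differs from compound 2 in one place: methylsulfonyl in place of (trifluoromethyl)sulfanyl on an aromatic carbon. For the measured compounds named here, no measured step matches this exact change, so the step from compound 1 to compound 3 bears on it only loosely: it shows that exchanging the group at this end of the core can move this assay by a large amount. What the values of compound 1 and compound 3 show beside compound 2 is that the compound bearing (trifluoromethyl)sulfanyl lies far below both of the others. A large step toward a higher number is therefore expected, estimated as a 300-fold higher number from compound 2 to compound 4 (2.48 log units; beyond the scatter). For compound 4 the estimate in this assay is 120 nM, with a range from 10 nM to 1500 nM.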

Compound 4, half-maximal effective concentration: 3800 nM
For compound 4 the middle estimate is 32-fold (1.50 log units) below the measured one; measured number outside the range, above it.
By their numbers in this assay, from the lowest: compound 2; then compound 1; then compounds 4 and 3 (each within the scatter of the next).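

In this assay the exchange of (trifluoromethyl)sulfanyl for methylsulfonyl on the same aromatic carbon gives a 9500-fold higher number from compound 2 to compound 4 (3.98 log units; beyond the scatter) and so adds a second measured change at this end of the core. The earlier step, with amino and carboxy, was read on compounds carrying a chlorine on the ring, whereas this one is read on a core without it, and by the counts neither group here has a hydrogen-bond donor or a net charge, so a large step appears at this position even with both of those counts unchanged. No measurement shown explains why this exchange moves the number so far.

The compounds shown leave open which part of (trifluoromethyl)sulfanyl goes with the low number of compound 2, since a methylsulfanyl group or a trifluoromethyl group on the same aromatic carbon would separate the fluorine atoms from the sulfur and its oxygens. They also leave open whether (trifluoromethyl)sulfanyl or methylsulfonyl would give a step of similar size on the chlorine-bearing core of compound 1.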